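From 2-fluorophenyl to pyridin-2-yl on a shared core

A few compounds are considered here, and "the series" means these few. Any claim that something is new, unique, unknown or untested is made for them only; others in the source may bear on it.

Measured in an ADME assay on microsomes from liver (Mus musculus) for metabolic stability, read by HPLC, with a stated time of 4 h (on this read-out lower numbers stand for slow clearance and higher numbers for fast clearance), so far:
Compound 1 `CN(C)c1ccc2cc(-c3ccccc3F)c(N)nc2c1` gives > 500 mL/min/kg (a limit of the assay)
Compound 2 `CN(C)c1ccc2cc(-c3cc(Cl)ccc3Cl)c(N)nc2c1` gives > 500 mL/min/kg (a limit of the assay)
Compound 3 `CN(C)c1ccc2cc(-c3cc(Cl)cc(Cl)c3)c(N)nc2c1` gives 210 mL/min/kg (a number)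

Compound 1 stands at the limit of > 500 mL/min/kg in this assay, at which 2 of the 3 values shown sit, and so has no exact number. Compound 4 `CN(C)c1ccc2cc(-c3ccccn3)c(N)nc2c1` carries pyridin-2-yl in place of the 2-fluorophenyl of compound 1 on an aromatic carbon, ortho to an amino group pyridin-2-yl in place of 2-fluorophenyl on an aromatic carbon and is still to be measured. Among the measured compounds shown here, no measured pair isolates this change, but compound 3 (210 mL/min/kg) shows that the shared core can give an exact number. In this assay the expected step of an at least 1.7-fold lower number from compound 1 to compound 4 (0.25 log units; that floor lies within the scatter) is a fall in clearance, possibly a modest one. For compound 4 the estimate is 280 mL/min/kg (expected range 120 mL/min/kg to 600 mL/min/kg).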

Compound 4, clearance: > 500 mL/min/kg
Compound 4 ended at the assay's limit; the forecaster's own chance of this, stated with the estimate: 25%; at least 1.7-fold (0.25 log units) between middle value and limit.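

Among the compounds shown here, compound 4 ends at the same limit as compound 1, so no step between the two can be read: the limit of > 500 mL/min/kg in this assay, at which 3 of the 4 values shown sit. The compounds shown leave open how pyridin-2-yl and 2-fluorophenyl compare on the shared core in this assay.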